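A few compounds are considered here, and "the series" means these few. Any claim that something is new, unique, unknown or untested is made for them only; others in the source may bear on it.

Compound 1 `CC(C)c1n[nH]c2c(NCc3ccc(-c4ccccn4)cc3)nc(SCCCN(C)C)nc12` carries a 3-(dimethylamino)propyl on the sulfur of the shared core and gives 105 nM in a functional assay on HT cells (Homo sapiens) for antiproliferative activity, read by fluorescence, with a stated time of 72 h (a higher number here means a weaker inhibitor of growth, a lower number a stronger inhibitor of growth), the lowest number of the three measured. Compound 2 `CC(C)c1n[nH]c2c(NCc3ccc(-c4ccccn4)cc3)nc(SC3CCCCC3O)nc12` gives 636 nM in this assay, and compound 3 `CC(C)c1n[nH]c2c(NCc3ccc(-c4ccccn4)cc3)nc(SCC(N)CN)nc12` gives 480 nM. Both changes away from compound 1 cost potency: a 6.1-fold higher number from compound 1 to compound 2 (0.78 log units; beyond the scatter), and a 4.6-fold higher number from compound 1 to compound 3 (0.66 log units; beyond the scatter). Between the two replacements the gap is small, a 1.3-fold lower number from compound 2 to compound 3 (0.12 log units; within the scatter).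

Compound 4 `CSCCSc1nc(NCc2ccc(-c3ccccn3)cc2)c2[nH]nc(C(C)C)c2n1` differs from compound 1 only in the chain on the sulfur: methylsulfanyl in place of (dimethylamino)methyl on a saturated chain carbon, two bonds along the chain from a sulfur. Both measured steps that swap out the 3-(dimethylamino)propyl in compound 1 bear on this change, and both moved the number up by a modest amount; neither step swapped it for a 2-(methylsulfanyl)ethyl, so the exact size is uncertain. A loss of similar size in this assay is therefore expected, direction upward, with the estimated step of a 4.0-fold higher number from compound 1 to compound 4 (0.60 log units; beyond the scatter). Compound 4 is estimated at 420 nM, with a range from 150 nM to 1200 nM.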

Compound 4, concentration for 50% growth inhibition: 975 nM
Estimate against measurement, compound 4: 2.3-fold (0.37 log units) below, within the range that was stated.
By their numbers in this assay, from the lowest: compound 1; then compounds 3, 2 and 4 (each within the scatter of the next, the first and the last beyond it).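

In this assay, the step of a 9.3-fold higher number from compound 1 to compound 4 (0.97 log units; beyond the scatter) is the largest seen so far at this chain on the sulfur, and compound 1 remains the lowest of the four, with every step away from it beyond the scatter. The sulfur-bearing chain of compound 4 also separates it from the diamine chain, a 2.0-fold higher number from compound 3 to compound 4 (0.31 log units; beyond the scatter), but not from the 2-hydroxycyclohexyl, a 1.5-fold higher number from compound 2 to compound 4 (0.19 log units; within the scatter), a step within the scatter. All three replacements of the 3-(dimethylamino)propyl therefore land well above compound 1, whether they carry an amine, a hydroxyl or a methylsulfanyl.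

The change to compound 4 alters the chain length and the end group together, so a 2-(dimethylamino)ethyl or a 3-(methylsulfanyl)propyl on the sulfur would be needed to separate the two. No measurement at hand explains these steps.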